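The source may hold more compounds than are shown below. What is called first, only, known or untested is meant among the compounds shown, and "the series" means these compounds.

Of the compounds shown here, three sharing one core have been measured in a functional assay on NCI-H460 cells (Homo sapiens); a higher number here means that more compound is needed for the effect, a lower number that less compound is needed. Compound 1 `COc1cc(C2OC(c3ccc(N(C)C)cc3)=NN2C(C)=O)cc(OC)c1OC` gives 0.044 uM, compound 2 `COc1cc(C2OC(c3cccc(N(C)C)c3)=NN2C(C)=O)cc(OC)c1OC` gives 0.26 uM, and compound 3 `COc1cc(C2OC(c3ccc(N(C)C)cc3)=NN2C(=O)COC(C)=O)cc(OC)c1OC` gives 0.072 uM. Compound 3 and compound 1 lie within the scatter of each other, while the number for compound 2 stands clearly higher than that for compound 3.

The next structure, compound 4 `COc1cc(C2OC(c3ccc(N(C)C)cc3)=NN2C(=O)CN)cc(OC)c1OC`, differs from compound 3 in one group: amino in place of acetoxy on a saturated chain carbon bound to a carbonyl carbon. In words, this is amino in place of acetoxy on a saturated chain carbon bound to a carbonyl carbon.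

Two measured steps are available, and only one of them touches this place. That step, a 1.6-fold higher number from compound 1 to compound 3 (0.21 log units; within the scatter), put acetoxy where hydrogen had been and stayed within the scatter. The other step, a 5.9-fold higher number from compound 1 to compound 2 (0.77 log units; beyond the scatter), is larger but concerns a different place, one that the new structure leaves unchanged. Among the compounds with values here, no measured compound carries amino at the site in question, so the data offer no direct test of it.

Starting from compound 3 at 0.072 uM, no step beyond the scatter is therefore expected in this assay. The estimated step is a 1.0-fold lower number from compound 3 to compound 4 (0.01 log units; within the scatter), with no firm direction. For compound 4 the estimate is 0.07 uM, with an expected range from 0.02 uM to 0.25 uM.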

Compound 4, concentration for half-maximal effect: 0.66 uM
Beside the measured number, compound 4's estimate is 9.4-fold (0.97 log units) below it; measured number outside the range, above it.
By their numbers in this assay, from the lowest: compounds 1 and 3 (each within the scatter of the next); then compound 2; then compound 4.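

In this assay, the saturated chain carbon bound to a carbonyl carbon proves sensitive to which group it carries: amino in place of acetoxy gives a 9.2-fold higher number from compound 3 to compound 4 (0.96 log units; beyond the scatter) whereas acetoxy in place of hydrogen had stayed within the scatter. Amino in place of hydrogen at the same carbon gives a 15-fold higher number from compound 1 to compound 4 (1.18 log units; beyond the scatter) so the site tolerates one added group and not the other, and the count of heavy atoms does not order these three compounds, since amino, with fewer heavy atoms than acetoxy, gives the larger step away from compound 1. No supporting information on the compounds bears on why the amino group behaves so differently here.

The three compounds alone cannot show whether this sensitivity belongs to the amino group in particular, and a hydroxy group, a dimethylamino group, an acetamido group or a longer chain ending in an amine at this carbon would help separate the possibilities. Going by these compounds, it also remains open whether the same change would have a comparable effect alongside the 3-(dimethylamino)phenyl group of compound 2.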